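A Carboxymethyl for a Methoxy on the Aryl Ring

This account rests on a few compounds, and the source may have more. Where it says the series, first, only, none or still open, it means among the compounds named here.

Compound 1 `CC1CC/C(=N\Nc2ccccc2Cl)c2ncc(C(=O)O)c(=O)n21` gives > 1000 umol/kg, which is a limit of the assay. Compound 2 `CC1CC/C(=N\Nc2ccccc2Br)c2ncc(C(=O)O)c(=O)n21` gives > 320 umol/kg, also a limit of the assay. Compound 3 `COc1ccc(N/N=C2\CCC(C)n3c2ncc(C(=O)O)c3=O)cc1` gives 7.6 umol/kg.

In a functional assay on the whole organism for inhibition, with Rattus norvegicus as the target (on this read-out lower numbers stand for an effect already at smaller amounts and higher numbers for an effect only at larger amounts of compound), compound 3 holds the only actual number among the three values; the other two are limits, as shown in the limit of > 1000 umol/kg in this assay, at which 1 of the 3 values shown sits, and (the limit of > 320 umol/kg in this assay, at which 1 of the 3 values shown sits). The steps measured so far all concern the aryl group on the amine nitrogen: an at least 130-fold lower number from compound 1 to compound 3 (2.11 log units; beyond the scatter) and an at least 42-fold lower number from compound 2 to compound 3 (1.62 log units; beyond the scatter), while a step that the two limits leave unreadable from compound 1 to compound 2. Both readable steps are large and point the same way, toward the 4-methoxyphenyl of compound 3.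

Compound 4 `CC1CC/C(=N\Nc2ccc(CC(=O)O)cc2)c2ncc(C(=O)O)c(=O)n21` differs from compound 3 by carboxymethyl in place of methoxy on an aromatic carbon. Within the data shown here, this change keeps the aryl ring and its substitution place but swaps the group itself; no measured step varies a para group alone, so none of them bears directly on it. The expectation must therefore be loose. Compound 4 is expected to give 30 umol/kg, with a range from 5 umol/kg to 200 umol/kg. This estimate means a step of a 3.9-fold higher number from compound 3 to compound 4 (0.60 log units; beyond the scatter), expected as a rise beyond the scatter, with a real chance that only a limit is reported.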

Compound 4, dose for 50% inhibition: > 100 umol/kg
Compound 4: a limit, no number (the forecaster's own chance of this, stated with the estimate: 25%); at least 3.3-fold (0.52 log units) between middle value and limit.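

Compounds 1 and 2 differ from compound 3 in the whole aryl group on the amine nitrogen, whereas this pair differs only in the group on an aromatic carbon para to a large group. In this assay, that single change gives an at least 13-fold higher number from compound 3 to compound 4 (1.11 log units; beyond the scatter), so the low number of compound 3 depends on the methoxy itself and is not secured by the 4-substituted aryl ring alone. Compound 4 gives a limit and not a number, which leaves compound 3 with the only actual number among the four compounds: the limit of > 100 umol/kg in this assay, at which 1 of the 4 values shown sits.

The compounds shown leave open whether the rise follows from the longer chain or from the carboxylic acid at its end, a question that a methyl ester of the same chain or a plain ethyl group at this place would help to separate. They also leave open whether a methoxy at another place on the ring, or a chloro or bromo at this place, would keep a low number, since compounds 1 and 2 differ from compound 3 in both the group and its place.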